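Hydroxymethyl on the Aromatic Ring of Compound 2

The compounds below may be only part of what the source reports. "The series", "measured", "known", "first", "only" and "open" are said of these compounds alone.

Measured so far in an assay on membranes from brain for displacement of a labelled ligand from Sigma non-opioid intracellular receptor 1 (Cavia porcellus), read by scintillation counting, with a stated time of 120 min; on this read-out higher numbers stand for weaker inhibition and lower numbers for stronger inhibition:
Compound 1 `c1ccc(CCCNC2CCc3ccsc3CC2)cc1` gives 187 nM.
Compound 2 `CN(CCCc1ccccc1)C1CCc2ccsc2CC1` gives 10 nM.
Compound 3 `CCN(CCCc1ccccc1)C1CCc2ccsc2CC1` gives 17 nM.

Compound 2 has the lowest number of the three in this assay. Putting methyl in place of the hydrogen on the amine nitrogen gave a 19-fold lower number from compound 1 to compound 2 (1.27 log units; beyond the scatter), and putting ethyl there gave an 11-fold lower number from compound 1 to compound 3 (1.04 log units; beyond the scatter). Between the methyl and ethyl compounds the difference is a 1.7-fold higher number from compound 2 to compound 3 (0.23 log units; within the scatter), so these two cannot be told apart.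

Compound 4 `CN(CCCc1ccccc1)C1CCc2cc(CO)sc2CC1` differs from compound 2 in one place: hydroxymethyl in place of hydrogen on an aromatic carbon. Within the data shown here, all three measured steps change only the group on the amine nitrogen; none touches the aromatic ring, so no measured step bears directly on this change. In this assay, a step not beyond the scatter is therefore the expectation, with wider uncertainty than usual. The estimated step is a 2.0-fold higher number from compound 2 to compound 4 (0.30 log units; within the scatter). Compound 4 is estimated at 20 nM, expected between 5 nM and 80 nM.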

Compound 4, inhibition constant: 6.4 nM
The estimate for compound 4 lay 3.1-fold (0.49 log units) above the measured number; low and high end bracket the measured number.
By their numbers in this assay, from the lowest: compounds 4, 2 and 3 (each within the scatter of the next, the first and the last beyond it); then compound 1.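

In this assay, among these compounds, the aromatic ring of the shared core carries an added group for the first time, and hydroxymethyl on the aromatic carbon next to the ring sulfur gives a 1.6-fold lower number from compound 2 to compound 4 (0.19 log units; within the scatter) and so no step that can be told from the scatter. The earlier compounds shown here showed large steps only at the amine nitrogen, on going from hydrogen to methyl or ethyl; this carbon of the ring now stands as a place where a group with a hydrogen-bond donor and acceptor leaves the number in the range of compound 2. Nothing measured here offers a reason for this result.

Going by these compounds, whether the oxygen matters remains open, as a plain methyl on the same carbon would be needed to tell. So does whether a carboxylic acid, an amine or a longer chain there would keep the number in this range.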